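The source may report more compounds than this note shows. Statements on the series, on what has been measured and on what is new or still open speak of the compounds shown alone.

Measured compounds in an ADME assay on stomach for pharmacokinetics, in simulated gastric fluid; on this read-out lower numbers stand for a shorter-lived compound and higher numbers for a longer-lived compound:
- compound 1 `CCOc1cc(NC(=O)C2(NC(=O)c3ccc4c(C5CCCC5)c(-c5ncc(Cl)cn5)n(C)c4c3)CCC2)ccc1/C=C/C(=O)N[C@@H](CCCNC(=N)N)C(N)=O` gives 0.467 h
- compound 2 `CCOc1cc(NC(=O)C2(NC(=O)c3ccc4c(C5CCCC5)c(-c5ncc(Cl)cn5)n(C)c4c3)CCC2)ccc1/C=C/C(=O)OCOP(=O)(O)O` gives 1.3 h
- compound 3 `CCCOC(=O)/C=C/c1ccc(NC(=O)C2(NC(=O)c3ccc4c(C5CCCC5)c(-c5ncc(Cl)cn5)n(C)c4c3)CCC2)cc1OCC` gives 2.23 h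

Compound 3 holds the highest of the three numbers in this assay: a 4.8-fold higher number from compound 1 to compound 3 (0.68 log units; beyond the scatter), whereas a 1.7-fold higher number from compound 2 to compound 3 (0.23 log units; within the scatter), so the values of compound 2 and compound 3 cannot be told apart. Compound 4 `CCOc1cc(NC(=O)C2(NC(=O)c3ccc4c(C5CCCC5)c(-c5ncc(Cl)cn5)n(C)c4c3)CCC2)ccc1/C=C/C(=O)OCC(C)C` differs from compound 3 by methyl in place of hydrogen on a saturated chain carbon bound to two saturated chain carbons. Among the compounds with values here, none of the measured steps speaks directly to this change. a 2.8-fold higher number from compound 1 to compound 2 (0.44 log units; beyond the scatter) and a 4.8-fold higher number from compound 1 to compound 3 (0.68 log units; beyond the scatter) both concern exchange of the whole group on the carbonyl carbon, and a 1.7-fold higher number from compound 2 to compound 3 (0.23 log units; within the scatter) exchanges groups on the chain carbon bound to the oxygen. The methyl added in compound 4 sits further out along the ester chain and has no counterpart among these steps. With the ester retained and only a single methyl added, no step beyond the scatter is expected in this assay; the expected change is a 1.0-fold higher number from compound 3 to compound 4 (0.01 log units; within the scatter). Compound 4 is therefore estimated at 2.3 h, with a range from 1.2 h to 4.5 h.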

Compound 4, half-life: 1.43 h
The estimate for compound 4 lay 1.6-fold (0.21 log units) above the measured number; measured number inside the range.
By their numbers in this assay, from the lowest: compound 1; then compounds 2, 4 and 3 (each within the scatter of the next).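

In this assay, the change from propoxy to isobutoxy is the only step shown that alters the ester chain alone, and methyl in place of hydrogen on this saturated chain carbon gives no separation (a 1.6-fold lower number from compound 3 to compound 4 (0.19 log units; within the scatter)). The isobutyl ester of compound 4 also cannot be told apart from the phosphorus-bearing ester (a 1.1-fold higher number from compound 2 to compound 4 (0.04 log units; within the scatter)), while the step from the amide stands beyond the scatter (a 3.1-fold higher number from compound 1 to compound 4 (0.49 log units; beyond the scatter)), as the steps to the other two esters do. Nothing available bears on the reason for these numbers.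

Open, on these data alone, is whether a longer chain or a cyclohexyl group on the ester oxygen would separate from the propyl and isobutyl esters. Also open, as far as these compounds go, is how a carboxylic acid in place of the ester would read here.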